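The compounds below may be only part of what the source reports. "The series", "measured", "known", "first", "only" and "open" are said of these compounds alone.

Compound 3 `CCN1CCN(CCCn2cnc3c(N4CCN(CC)CC4)nc(NC(=O)c4ccccc4)nc32)CC1` is built on the shared core and carries a benzoyl group on the exocyclic nitrogen. In an assay on HEK293 cells for antagonist activity at Toll-like receptor 9 (Homo sapiens), read by spectrophotometry (a higher number here means a weaker inhibitor, a lower number a stronger inhibitor), compound 3 gives 340 nM, the highest of the three numbers measured here. Compound 1 `CCN1CCN(CCCn2cnc3c(N4CCN(CC)CC4)nc(NCc4ccccc4)nc32)CC1`, which bears a benzyl group in the same place, gives 140 nM; compound 2 `CCN1CCN(CCCn2cnc3c(N4CCN(C5CCCC5)CC4)nc(NCc4ccc(F)cc4)nc32)CC1`, with a 4-fluorobenzyl group and a cyclopentyl on the piperazine, gives 250 nM. Compound 4 `CCN1CCN(CCCn2cnc3c(N4CCN(CC)CC4)nc(NCc4ccc(F)cc4)nc32)CC1` is not yet measured. It differs from compound 3 by 4-fluorobenzyl in place of benzoyl on a nitrogen on an aromatic ring. Among the measured compounds shown here, the only measured step that bears on this change is a 2.4-fold higher number from compound 1 to compound 3 (0.39 log units; beyond the scatter), which runs in the opposite direction, benzyl to benzoyl. Compound 4 therefore reverses that step, with a fluorine added on the benzyl ring. For the measured compounds named here, no measured pair isolates the fluorine alone, since compound 2 and compound 1 differ in two places. On that basis compound 4 is expected to fall near compound 1, with the reverse of the measured step. The expected step is a 2.3-fold lower number from compound 3 to compound 4 (0.36 log units; beyond the scatter). Compound 4 is estimated at 150 nM, between 60 nM and 400 nM.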

Compound 4, half-maximal inhibitory concentration: 470 nM
For compound 4 the middle estimate is 3.1-fold (0.50 log units) below the measured one; measured number outside the range, above it.
By their numbers in this assay, from the lowest: compounds 1, 2, 3 and 4 (each within the scatter of the next, the first and the last beyond it).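

Fluoro in place of hydrogen on an aromatic carbon of the benzyl group now stands as a single change, and it gives a 3.4-fold higher number from compound 1 to compound 4 (0.53 log units; beyond the scatter), so in this assay this one atom on the ring is enough to separate two compounds. The two other changes do not separate theirs: 4-fluorobenzyl in place of benzoyl on a nitrogen on an aromatic ring gives a 1.4-fold higher number from compound 3 to compound 4 (0.14 log units; within the scatter), and ethyl in place of cyclopentyl on an amine nitrogen in a ring gives a 1.9-fold higher number from compound 2 to compound 4 (0.27 log units; within the scatter). Nothing at hand accounts for the effect of the fluorine. The compounds shown leave open whether a chlorine or a methoxy group on the benzyl ring would act as fluoro does. They also leave open how a 4-fluorobenzoyl group on that nitrogen would compare with benzoyl.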